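Heptyloxy for tert-butyl: an expected result in paw edema

The source may hold more compounds than are shown below. What is called first, only, known or untested is meant among the compounds shown, and "the series" means these compounds.

Measured so far:
compound 1 `CCOC(=O)C1CCN(C(=O)c2cc(-c3ccc(C)cc3)nn2Cc2ccccc2)CC1` — 54.4% in a functional assay on the whole organism (strain Swiss albino) for inhibition, with Mus musculus as the target, read by paw edema, with stated times of 30 min and 270 min, at a dose of 100 mg/kg by the subcutaneous route; a lower number here means less inhibition, a higher number more inhibition at the dose given (going by the name of the read-out)
compound 2 `Cc1ccc(-c2cc(C(=O)NCc3cccnc3)n(Cc3ccccc3)n2)cc1` — 24.4%
compound 3 `Cc1ccc(-c2cc(C(=O)Oc3ccc(C(C)(C)C)cc3)n(Cc3ccccc3)n2)cc1` — 50%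

Compound 3 stands second highest of the three. Its nearest neighbour is compound 1, whose number lies higher but within the usual scatter, so no order between the two can be read. Compound 2 lies furthest, lower by a margin beyond the scatter.

Compound 4 `CCCCCCCOc1ccc(OC(=O)c2cc(-c3ccc(C)cc3)nn2Cc2ccccc2)cc1` has not yet been measured in this assay. It differs from compound 3 in one place: heptyloxy in place of tert-butyl on an aromatic carbon. Within the data shown here, no step between measured compounds shows what such a change does, since the three measured compounds vary elsewhere. With nothing to anchor a direction, compound 4 is expected to sit near compound 3, and the step of a number 2 percentage points lower from compound 3 to compound 4 (within the scatter) is expected to stay within the scatter. The estimate for compound 4 is 48%, between 30% and 65%.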

Compound 4, a percentage reported as inhibition, in the whole organism at one dose (the size of the read-out at that dose, not a potency): 10%
For compound 4 the middle estimate is 38 percentage points above the measured one; measured number below the stated range.
By their numbers in this assay, from the lowest: compound 4; then compound 2; then compounds 3 and 1 (each within the scatter of the next).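

Heptyloxy in place of tert-butyl on this aromatic carbon gives a number 40 percentage points lower from compound 3 to compound 4 (beyond the scatter) in this assay, which shows that the read-out is sensitive to the group at this position, para to a large group. The earlier compounds shown here varied elsewhere and could not show this. Nothing at hand says why the number falls.

Among these compounds, the single step leaves open whether the oxygen or the length of the chain matters, which a methoxy or a plain heptyl group could separate. As far as these compounds go, how an amine or a carboxylic acid would fare at this position also remains open.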